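Selenocyanate and thiocyanate derivatives of the shared acetylsalicyloyl core

The compounds below may be only part of what the source reports. "The series", "measured", "known", "first", "only" and "open" are said of these compounds alone.

Measured so far:
compound 1, `CC(=O)Oc1ccccc1C(=O)OCC[Se]C#N`, 33900 nM
compound 2, `CC(=O)Oc1ccccc1C(=O)[Se]CC[Se]C(=O)c1ccccc1OC(C)=O`, 17200 nM

Both compounds were tested in a functional assay on UACC-903 cells (Homo sapiens) for antiproliferative activity, read by MTT assay, with a stated time of 24 h; a lower number here means a stronger inhibitor, a higher number a weaker inhibitor. Compound 1 has the higher of the two numbers; compound 2 sits a small distance away, and that distance is within the scatter, so the two values cannot be ordered against each other. Among the measured compounds shown here, no pair of measured compounds differs in one place, so no measured step is available to lean on.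

Compound 3, `CC(=O)Oc1ccccc1C(=O)NCCSC#N`, has not yet been measured in this assay. It differs from compound 1 by a group of 6 heavy atoms (3 carbon, 2 nitrogen, 1 sulfur; no ring) in place of a group of 6 heavy atoms (3 carbon, 1 nitrogen, 1 oxygen, 1 selenium; no ring), on a carbonyl carbon. The exchange replaces the ester oxygen with an amino group and the selenium with sulfur while keeping the chain length and the nitrile. With no measured step of this kind in the series, the expectation is for a step from compound 1 to compound 3 of a 1.2-fold higher number from compound 1 to compound 3 (0.07 log units; within the scatter), that is, no change beyond the scatter, with weak activity on both sides. For compound 3 the expected value in this assay is 40000 nM, with a range from 12000 nM to 150000 nM.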

Compound 3, half-maximal inhibitory concentration: > 50000 nM
Compound 3: no number, only a limit; the forecaster's own chance of this, stated with the estimate: 25%; at least 1.2-fold (0.09 log units) between middle value and limit.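

In this assay compound 3 reads > 50000 nM, which is a limit of the assay and not a number. This gives the series its first step between compounds that differ in one place, on a carbonyl carbon whose other neighbour is an aromatic carbon, where (2-(cyanosulfanyl)ethyl)amino enters, and it amounts to an at least 1.4-fold higher number from compound 1 to compound 3 (0.16 log units; that floor lies within the scatter), so this exchange is not shown to have moved the reading beyond the scatter, and no gain in potency appears in it. Only the floor of the step is known, and its true size stays unread, as the reading of compound 3 ends at the top of the measurable range: the limit of > 50000 nM in this assay, at which 1 of the 3 values shown sits.

The step exchanges the ester oxygen for an amino group and the selenium for sulfur in a single move, and the compounds shown do not separate the two exchanges. On these data alone, whether an amide carrying a selenocyanate, an ester carrying a thiocyanate or a longer chain ending in either group would give a number rather than a limit remains open.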